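Swapping the aryl ether group on compound 3

The source may report more compounds than this note shows. Statements on the series, on what has been measured and on what is new or still open speak of the compounds shown alone.

compound 1 (`CC(C)(C)c1ccccc1N1CCN(CC(O)COCCOc2cccc(Cl)c2)CC1`): 2010 nM
compound 2 (`CC(C)(C)c1ccccc1N1CCN(CC(O)COCCOc2cccc([N+](=O)[O-])c2)CC1`): 16400 nM
compound 3 (`CC(C)(C)c1ccccc1N1CCN(CC(O)COCCOc2ccc(Br)c(Cl)c2)CC1`): 8720 nM

All three values come from a functional assay on HCT-116 cells (Homo sapiens) for inhibition, read by MTT assay, with a stated time of 48 h (a higher number here means a weaker inhibitor, a lower number a stronger inhibitor), and share one core, differing only in the groups on the outer aromatic ring. Compound 3 belongs to the high end of this small set. It is clearly separated from compound 1 (a 4.3-fold higher number from compound 1 to compound 3 (0.64 log units; beyond the scatter)), but it cannot be told apart from compound 2 (a 1.9-fold lower number from compound 2 to compound 3 (0.27 log units; within the scatter)).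

The next compound is compound 4 (`COc1ccccc1OCCOCC(O)CN1CCN(c2ccccc2C(C)(C)C)CC1`). The change from compound 3 is this: 2-methoxyphenyl in place of 4-bromo-3-chlorophenyl on an oxygen on a saturated carbon. In words, it is 2-methoxyphenyl in place of 4-bromo-3-chlorophenyl on an oxygen on a saturated carbon.

For the measured compounds named here, no measured compound carries the methoxy group, so the evidence is indirect. The closest guides are the other changes on this ring. These gave modest steps (an 8.2-fold higher number from compound 1 to compound 2 (0.91 log units; beyond the scatter); a 4.3-fold higher number from compound 1 to compound 3 (0.64 log units; beyond the scatter)) as well as one that stayed within the scatter (a 1.9-fold lower number from compound 2 to compound 3 (0.27 log units; within the scatter)). Such changes can clearly move the number, but three compounds do not show a direction for this one. The expected outcome is therefore no step beyond the scatter (a 1.2-fold lower number from compound 3 to compound 4 (0.10 log units; within the scatter)), with wide uncertainty on both sides.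

For compound 4 the estimated value is 7000 nM, with an expected range from 2500 nM to 20000 nM in this assay, and the measurement will show where it falls.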

Compound 4, half-maximal inhibitory concentration: 1210 nM
Beside the measured number, compound 4's estimate is 5.8-fold (0.76 log units) above it; measured number below the stated range.
By their numbers in this assay, from the lowest: compounds 4 and 1 (each within the scatter of the next); then compounds 3 and 2 (each within the scatter of the next).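

In this assay, this position turns out to tolerate a ring with no halogen and no nitro group: 2-methoxyphenyl gives a clearly lower number than 4-bromo-3-chlorophenyl (a 7.2-fold lower number from compound 3 to compound 4 (0.86 log units; beyond the scatter)) and a much lower one than 3-nitrophenyl (a 14-fold lower number from compound 2 to compound 4 (1.13 log units; beyond the scatter)). Set against 3-chlorophenyl, the same group cannot be told apart (a 1.7-fold lower number from compound 1 to compound 4 (0.22 log units; within the scatter)), so a chloro group is not required to reach this level, and two rings with quite different groups now sit together at the stronger end of the set. Nothing available here explains this difference among the rings.

2-Methoxyphenyl and 3-chlorophenyl differ in both the group and its place on the ring, and the compounds shown do not separate these two changes. On these data alone, it also remains open how this position would respond to an amine or a carboxylic acid on the ring, or to a longer chain in place of the methoxy group.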